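The compounds below may be only part of what the source reports. "The series", "measured", "known", "first", "only" and "open" are said of these compounds alone.

The series shares one core, carrying a cyclic amine on the fused ring. Among the measured compounds shown here, in an assay on isolated protein for inhibition of DNA topoisomerase 1 (Homo sapiens), with a stated time of 15 min (a higher number here means a weaker inhibitor, a lower number a stronger inhibitor), compound 2 `O=C(O)c1cn(Cc2ccc(-c3ccccc3)cc2)c2cc(N3CC4CNCC4C3)c(F)cc2c1=O` gives 33300 nM and is the only compound with a numerical result. Compound 1 `COc1c(N2CC[C@@H](CO)C2)c(F)cc2c(=O)c(C(=O)O)cn(Cc3ccc(-c4ccccc4)cc3)c12` sits at a limit of the assay, > 200000 nM. Compound 3 `CNC[C@@H]1CCN(c2cc3c(cc2F)c(=O)c(C(=O)O)cn3Cc2ccc(-n3cccn3)cc2)C1` likewise reaches only a limit, > 200000 nM. Set against (the limit of > 200000 nM in this assay, at which 2 of the 3 values shown sit), compound 2 stands as the sole measured inhibitor here. Compound 4 `O=C(O)c1cn(Cc2ccc(-c3ccccc3)cc2)c2cc(NC[C@H]3CCNC3)c(F)cc2c1=O`, not yet measured, differs from compound 2 by a group of 7 heavy atoms (5 carbon, 2 nitrogen; one five-membered non-aromatic ring with 1 hetero atom) in place of a group of 8 heavy atoms (6 carbon, 2 nitrogen; 2 five-membered non-aromatic rings with 1 hetero atom each), on an aromatic carbon. For the measured compounds named here, no measured pair differs in a single place, so the size of this step is open. The estimated step is a 2.1-fold higher number from compound 2 to compound 4 (0.32 log units; beyond the scatter), toward weaker inhibition and modestly beyond the scatter. For compound 4 the expected value in this assay is 70000 nM, within 20000 nM to 200000 nM, with a real chance of only a limit.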

Compound 4, half-maximal inhibitory concentration: 100000 nM
Compound 4: the middle estimate sits 1.4-fold (0.15 log units) below what was measured; low and high end bracket the measured number.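

In this assay, among the compounds shown here, putting ((pyrrolidin-3-yl)methyl)amino in place of the two-ring group on this aromatic carbon, ortho to a fluoro group, gives a 3.0-fold higher number from compound 2 to compound 4 (0.48 log units; beyond the scatter), the first readable step. The position therefore still gives a numerical result with a single five-membered ring, though the inhibition is modestly weaker. Little room remains on the weak side of the scale: the limit of > 200000 nM in this assay, at which 2 of the 4 values shown sit.

Still open, on these data alone, is how the opposite stereocentre of this group would read in this assay. Also open, as far as these compounds go, is how a piperazine or an azetidine would compare on the same carbon.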